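The source may report more compounds than this note shows. Statements on the series, on what has been measured and on what is new or still open speak of the compounds shown alone.

Compound 2 `COc1cc(/C=C\c2ccc(B(O)O)cc2)cc(OC)c1`, compound 1 `COc1cc(/C=C\c2ccc(B(O)O)cc2)cc(OC)c1OC` and compound 3 `COc1cc(/C=C\c2cccc(B(O)O)c2)cc(OC)c1` were tested in a functional assay on B16 cells (Mus musculus) for cytotoxicity; a lower number here means a stronger inhibitor, a higher number a weaker inhibitor. Compound 2 gives 12000 nM, compound 1 gives 2600 nM and compound 3 gives 1800 nM. Between compound 2 and compound 1 the change is methoxy in place of hydrogen on an aromatic carbon, and the step is a 4.6-fold lower number from compound 2 to compound 1 (0.66 log units; beyond the scatter). Compound 3 and compound 2 are built from the same atoms joined differently; the difference between the two cores is not broken down here. Compound 4 `COc1cc(/C=C\c2ccc(OC)c(B(O)O)c2)cc(OC)c1` has not yet been measured in this assay. From compound 3 to compound 4 the change is methoxy in place of hydrogen on an aromatic carbon. It is the same kind of change as that from compound 2 to compound 1, not the same: in compound 1 the entering methoxy sits ortho to two methoxy groups, in compound 4 ortho to a group of 3 heavy atoms, in both cases para to a large group. Among the compounds with values here, only one measured example of this kind of change exists, in a different surrounding, so the expectation rests on that step alone and is held loosely. Compound 4 is expected to show a 1.5-fold lower number from compound 3 to compound 4 (0.18 log units; within the scatter), a smaller step than the earlier one because compound 3 already stands at 1800 nM, within the scatter of compound 1. The estimate for compound 4 is 1200 nM, between 400 nM and 4000 nM.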

Compound 4, half-maximal inhibitory concentration: 19 nM
For compound 4 the middle estimate is 63-fold (1.80 log units) above the measured one; measured number below the stated range.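

In this assay, methoxy in place of hydrogen on an aromatic carbon gives a 95-fold lower number from compound 3 to compound 4 (1.98 log units; beyond the scatter), and this step does not match the one seen on the other core: the same change on two cores in this assay, a 4.6-fold lower number (0.66 log units; beyond the scatter) from compound 2 to compound 1 and a 95-fold lower number (1.98 log units; beyond the scatter) from compound 3 to compound 4, 21-fold (1.31 log units) apart, beyond the scatter of two such steps The change lowers the number on both cores, so its direction carries over in these two pairs, but its size does not, and the step on one core gave no reliable measure of the step on the other. These two pairs do not show why the steps differ, since the methoxy enters a different surrounding in each, and they cannot separate the effect of the core from that of the place of entry.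

The compounds shown leave open whether the large step belongs to methoxy itself or would also appear with an ethoxy group, a hydroxyl group or an amine at that place. They also leave open whether it survives if a carboxylic acid takes the place of the boronic acid.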